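The compounds below may be only part of what the source reports. "The series", "measured", "known", "first", "only" and "open" are said of these compounds alone.

Measured so far in a functional assay on HepG2 cells (Homo sapiens) for inhibition, read by MTT assay, with a stated time of 72 h, tested at 50 uM; a lower number here means less inhibition of growth, a higher number more inhibition of growth at the concentration tested:
- compound 1 `C=CCc1ccc(OCc2cn(-c3ccccc3Cl)nn2)c(O)c1`: 4.7%
- compound 2 `C=CCc1ccc(OCc2cn(-c3cccc(C#N)c3)nn2)c(O)c1`: 3.4%

Compound 2, at 3.4%, lies within the scatter of compound 1, so the two cannot be ordered. Both numbers show little growth inhibition at the concentration tested.

Next is compound 3 `C=CCc1ccc(OCc2cn(-c3ccc(Br)cc3)nn2)c(O)c1`, with 4-bromophenyl in place of 3-cyanophenyl on an aromatic nitrogen.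

For the measured compounds named here, one measured step bears on this change: a number 1.3 percentage points lower from compound 1 to compound 2 (within the scatter). It is also an exchange of the substituted phenyl group on that nitrogen, and it stayed within the scatter. Going by the values given here, no 4-bromophenyl compound has been measured yet, so this evidence is thin. No shift beyond the scatter is expected, and the expected step is a number 2.6 percentage points higher from compound 2 to compound 3 (within the scatter). For compound 3 the estimate in this assay is 6%, with an expected range of 0% to 18%.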

Compound 3, percent growth inhibition at one concentration: 9.5%
Compound 3: the middle estimate sits 3.5 percentage points below what was measured; measured number inside the range.
By their numbers in this assay, from the lowest: compounds 2, 1 and 3 (each within the scatter of the next).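

In this assay, the step to 4-bromophenyl on the aromatic nitrogen reads a number 6.1 percentage points higher from compound 2 to compound 3 (within the scatter) and a number 4.8 percentage points higher from compound 1 to compound 3 (within the scatter). Both steps stay within the scatter, so this first para-free comparison of a bromine-bearing phenyl group with the nitrile-bearing and chlorine-bearing ones does not separate the three compounds. No measurement bears on the reason for these numbers.

From the compounds shown here alone, only substituted phenyl groups appear on this nitrogen, so an aminophenyl group, a carboxylic acid on the phenyl ring, or a saturated ring such as cyclohexyl in place of the phenyl remain open. Also open, going by these compounds, is whether any exchange at this position can move growth inhibition beyond the scatter at the concentration tested.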